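The source may report more compounds than this note shows. Statements on the series, on what has been measured and on what is new or still open speak of the compounds shown alone.

Compound 1 `Cc1c(Cc2ccccc2)c(=O)oc2cc(OCC(O)CNCc3cccs3)ccc12` and compound 2 `Cc1c(Cc2ccc(Br)cc2)c(=O)oc2cc(OCC(O)CN3CCC(C(N)=O)CC3)ccc12` share a common core and were both examined in an ADME assay on A549 cells (Homo sapiens) for cytotoxicity, read by CellTiter-Glo; on this read-out higher numbers stand for lower toxicity in this test and lower numbers for higher toxicity in this test. In this assay compound 1 gives 87300 nM. For compound 2 the outcome in this assay is a limit of the assay, > 100000 nM, so only a bound is known for it. Compound 2 thus stands at the limit of > 100000 nM in this assay, at which 1 of the 2 values shown sits. Compound 3 `COC(=O)c1ccc(Cc2c(C)c3ccc(OCC(O)CN4CCC(C(N)=O)CC4)cc3oc2=O)cc1` has not yet been measured. It differs from compound 2 in one place: methoxycarbonyl in place of bromo on an aromatic carbon, in words, methoxycarbonyl in place of bromo on an aromatic carbon. Going by the values given here, no step between two measured compounds is available to calibrate this change, so its effect can only be guessed. Compound 3 is expected to remain at about the same level, with the step from compound 2 to compound 3 estimated at a number no higher from compound 2 to compound 3 (the limit leaves the size open), not beyond the usual scatter. For compound 3 the value in this assay is estimated at 100000 nM, within a range from 50000 nM to 200000 nM. The most likely outcome for compound 3 is expected to be once more a limit rather than a number.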

Compound 3, half-maximal cytotoxic concentration: > 100000 nM
Compound 3 ended at the assay's limit; the forecaster's own chance of this, stated with the estimate: 65%; the middle value sits exactly at the limit.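

No step can be read between compound 2 and compound 3, because in this assay both results are limits of the assay and not numbers: the limit of > 100000 nM in this assay, at which 2 of the 3 values shown sit. The compounds shown leave open whether methoxycarbonyl in place of bromo on an aromatic carbon changes the result in this assay at all, and in which direction.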